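Two cores, one halogen swap: estimating a fluoro amide

The source may hold more compounds than are shown below. What is called first, only, known or untested is meant among the compounds shown, and "the series" means these compounds.

The measured compounds:
compound 1, `O=S(=O)(Nc1ccc2cc[nH]c2c1)c1ccc(F)cc1`, in a functional assay on T47D cells (Homo sapiens) for antiproliferative activity, read by MTT assay, with a stated time of 24 h; a higher number here means a weaker inhibitor, a lower number a stronger inhibitor: 33000 nM
compound 2, `O=S(=O)(Nc1ccc2cc[nH]c2c1)c1ccc(Br)cc1`, in this assay: 40100 nM
compound 3, `O=C(Nc1ccc2cc[nH]c2c1)c1ccc(Br)cc1`, in this assay: 63700 nM

Compounds 1 and 2 share one core and differ only at one spot: fluoro in place of bromo on an aromatic carbon. That change gave a 1.2-fold lower number from compound 2 to compound 1 (0.08 log units; within the scatter), so the two values are indistinguishable here.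

Compound 3 has a different core from compound 2; how the two cores differ is not broken down here. Among the three measured compounds, compound 3 carries the highest number, but its nearest neighbour, compound 2, lies within the scatter of it, and so does compound 1. No order among the three is therefore claimed.

Compound 4, `O=C(Nc1ccc2cc[nH]c2c1)c1ccc(F)cc1`, has not been measured in this assay. It stands to compound 3 as compound 1 stands to compound 2: fluoro in place of bromo on an aromatic carbon. The place is the same word for word in both cases, so this is the same change, made on the core of compound 3 instead of the core of compound 2.

The expectation for compound 4 rests on that single precedent. Because the change from compound 2 to compound 1 gave a 1.2-fold lower number from compound 2 to compound 1 (0.08 log units; within the scatter), compound 4 is expected to stay close to compound 3, with an estimated 1.2-fold lower number from compound 3 to compound 4 (0.06 log units; within the scatter). In this assay, compound 4 is estimated at 55000 nM, with a range expected from 20000 nM to 150000 nM.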

Compound 4, half-maximal inhibitory concentration: 35100 nM
The estimate for compound 4 lay 1.6-fold (0.20 log units) above the measured number; low and high end bracket the measured number.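

In this assay, going by these compounds alone, putting fluoro in place of bromo on the core of compound 3 gave a 1.8-fold lower number from compound 3 to compound 4 (0.26 log units; within the scatter), so on this core too the swap produced no step that can be told from the scatter. Set beside the earlier step, the change carried from one core to the other without a difference that can be resolved: the same change on two cores in this assay, a 1.2-fold lower number (0.08 log units; within the scatter) from compound 2 to compound 1 and a 1.8-fold lower number (0.26 log units; within the scatter) from compound 3 to compound 4, 1.5-fold (0.17 log units) apart, within the scatter of two such steps

Within the data shown here, this shows only that the swap left the number within the scatter on both cores, so it supports no ranking of fluoro against bromo and no claim that either core responds more strongly. With just two cores and a change that barely registers on either, it also cannot show that a larger step would transfer in the same way, or that this swap would behave alike on any other core.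

Fluoro and bromo are the only groups shown at this place, para to a large group, so the compounds leave open how a chloro, a methoxy, an amine or a carboxylic acid there would read in this assay. Also open, on these data alone, is what a methyl group or a longer chain elsewhere on either core would do to these numbers.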